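Methoxycarbonyl to carboxy on the shared core

This account rests on a few compounds, and the source may have more. Where it says the series, first, only, none or still open, it means among the compounds named here.

Measured in a functional assay on Raji cells (Homo sapiens); a higher number here means a weaker inhibitor, a lower number a stronger inhibitor:
- compound 1 `NC(=O)c1nn([C@@H]2O[C@H](CO)[C@@H](O)[C@H]2O)cc1I`: > 300000 nM (a limit of the assay)
- compound 2 `COC(=O)c1nn([C@@H]2O[C@H](CO)[C@@H](O)[C@H]2O)cc1I`: 200 nM

Within the data shown here, compound 2 holds the only exact number so far. The entry for compound 1 is a limit. Next comes compound 3 `O=C(O)c1nn([C@@H]2O[C@H](CO)[C@@H](O)[C@H]2O)cc1I`, with hydrogen in place of methyl on an oxygen next to a carbonyl group. Among the measured compounds shown here, one measured step bears on this, at the same carbonyl carbon: an at least 1500-fold lower number from compound 1 to compound 2 (3.17 log units; beyond the scatter). Given that large step, losing the methoxy is expected to raise the number substantially in this assay, though probably less far. The expected step is a 100-fold higher number from compound 2 to compound 3 (2.00 log units; beyond the scatter). The estimate for compound 3 is 20000 nM, with an expected range of 1500 nM to 300000 nM.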

Compound 3, half-maximal inhibitory concentration: > 300000 nM
Compound 3 ended at the assay's limit; the forecaster's own chance of this, stated with the estimate: 40%; middle value at least 15-fold (1.17 log units) away from the limit.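

In this assay, the methoxycarbonyl group now stands apart from both the amide and the carboxy group on the shared core: hydrogen in place of methyl on the oxygen gives an at least 1500-fold higher number from compound 2 to compound 3 (3.17 log units; beyond the scatter). Compound 3 gives > 300000 nM, a limit of the assay. The step from compound 1 to compound 3 cannot be read, and the series so far has one exact number: the limit of > 300000 nM in this assay, at which 2 of the 3 values shown sit.

Open, on these data alone, is whether an ethyl ester, a longer chain on that oxygen, or a methylamino group on the carbonyl carbon keeps a number close to that of compound 2.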